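The source may hold more compounds than are shown below. What is called first, only, known or untested is meant among the compounds shown, and "the series" means these compounds.

Compound 3 `O=C(c1cncc(Br)c1)N1N=C(c2ccc(Cl)cc2)CC1c1ccc(OCc2ccccc2)cc1` belongs to a small group of three compounds that share one core and differ in two outer groups. In a functional assay on WM 266-4 cells (Homo sapiens) for antiproliferative activity, read by MTT assay, with a stated time of 24 h (on this read-out lower numbers stand for stronger inhibition of growth and higher numbers for weaker inhibition of growth), compound 3 gives 8130 nM. Among the three numbers this is the second highest: compound 1 `COc1ccc(C2=NN(C(=O)c3cncc(Br)c3)C(c3ccc(OCc4ccccc4)cc3)C2)cc1` gives 6240 nM, and compound 2 `COc1ccc(C2=NN(C(=O)c3ccc(Cl)nc3)C(c3ccc(OCc4ccccc4)cc3)C2)cc1` gives 10600 nM; both neighbours sit within the scatter of compound 3, so no order between them can be claimed.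

Compound 4 `O=C(c1ccc(Cl)nc1)N1N=C(c2ccc(Cl)cc2)CC1c1ccc(OCc2ccccc2)cc1` is made from compound 3 by one change: 6-chloropyridin-3-yl in place of 5-bromopyridin-3-yl on a carbonyl carbon. The same exchange has already been seen once, on compound 1, where it gave a 1.7-fold higher number from compound 1 to compound 2 (0.23 log units; within the scatter). The other known step, a 1.3-fold higher number from compound 1 to compound 3 (0.11 log units; within the scatter), is also within the scatter, which suggests that the groups at the two changing places act independently and weakly here. The expected step is therefore small, leaning towards a higher number, as a 1.5-fold higher number from compound 3 to compound 4 (0.17 log units; within the scatter). On that basis compound 4 is estimated at 12000 nM, with a likely range from 5500 nM to 26000 nM.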

Compound 4, concentration for 50% growth inhibition: 13200 nM
Compound 4: middle estimate off by 1.1-fold (0.04 log units), on the low side, within the range that was stated.
By their numbers in this assay, from the lowest: compounds 1, 3, 2 and 4 (each within the scatter of the next, the first and the last beyond it).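

The exchange of 5-bromopyridin-3-yl for 6-chloropyridin-3-yl on a carbonyl carbon can now be read on a second core, where it gives a 1.6-fold higher number from compound 3 to compound 4 (0.21 log units; within the scatter), much the same step as on the core of compound 1: the same change on two cores in this assay, a 1.7-fold higher number (0.23 log units; within the scatter) from compound 1 to compound 2 and a 1.6-fold higher number (0.21 log units; within the scatter) from compound 3 to compound 4, 1.0-fold (0.02 log units) apart, within the scatter of two such steps

The change from methoxy to chloro on an aromatic carbon can also be read a second time, now with the 6-chloropyridin-3-yl group in place, giving a 1.2-fold higher number from compound 2 to compound 4 (0.10 log units; within the scatter), again matching the earlier step: the same change on two cores in this assay, a 1.3-fold higher number (0.11 log units; within the scatter) from compound 1 to compound 3 and a 1.2-fold higher number (0.10 log units; within the scatter) from compound 2 to compound 4, 1.0-fold (0.02 log units) apart, within the scatter of two such steps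

Among these compounds, each change therefore keeps its small size whichever group stands at the other place, and no compound here goes against this, so the two places look independent, although every one of these steps is within the scatter.

As far as these compounds go, every group on the carbonyl carbon here is a halogen-bearing pyridin-3-yl, so the effect of an amine or a carboxylic acid on that ring remains open. From the compounds shown here alone, it also remains open whether the two places would stay independent for a change that gives a larger step.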